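Chloro addition on the hydroxyphenyl ring of compound 2

A few compounds are considered here, and "the series" means these few. Any claim that something is new, unique, unknown or untested is made for them only; others in the source may bear on it.

For the measured compounds named here, in a functional assay on EJ cells (Homo sapiens) for cytotoxicity, with a stated time of 48 h (on this read-out higher numbers stand for weaker inhibition of growth and lower numbers for stronger inhibition of growth), compound 2 `Cc1cc(N2CCCS2(=O)=O)c2oc(-c3ccc(O)cc3)c(O)c(=O)c2c1` gives 270 nM, the lowest of the two numbers in hand; compound 1 `Cc1cc(N2C(=O)CN(C)C2=O)c2oc(-c3ccc(O)c(O)c3)c(O)c(=O)c2c1` gives 1100 nM, but these two differ in more than one place, so only the pair of values is read. Compound 3 `Cc1cc(N2CCCS2(=O)=O)c2oc(-c3ccc(O)c(Cl)c3)c(O)c(=O)c2c1` carries chloro in place of hydrogen on an aromatic carbon relative to compound 2. Going by the values given here, no single-place step is available to set the size of this change. The expected step is a 1.1-fold lower number from compound 2 to compound 3 (0.03 log units; within the scatter), a change that is estimated to stay within the usual scatter, with no firm direction. Compound 3 is estimated at 250 nM in this assay, between 100 nM and 700 nM.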

Compound 3, concentration for 50% growth inhibition: 65 nM
Compound 3: the middle estimate sits 3.8-fold (0.59 log units) above what was measured; the whole stated range lies above it.
By their numbers in this assay, from the lowest: compound 3; then compound 2; then compound 1.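

In this assay, for the compounds shown here, chloro in place of hydrogen on an aromatic carbon ortho to a hydroxy group gives a 4.2-fold lower number from compound 2 to compound 3 (0.62 log units; beyond the scatter) and so provides the first single-place step. This step lies beyond the scatter, which shows that the read-out responds to the change from 4-hydroxyphenyl to 3-chloro-4-hydroxyphenyl. No data at hand bear on the reason for this step. Open, from the compounds shown here alone, is how fluoro, bromo, methyl or methoxy would read at this same place. Also open, going by these compounds, is whether chloro gives a similar step on the core of compound 1.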